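The source may report more compounds than this note shows. Statements on the series, on what has been measured and on what is new or still open speak of the compounds shown alone.

Measured in an assay on isolated protein for inhibition of Amine oxidase [flavin-containing] A (Homo sapiens), read by fluorescence, with a stated time of 15 min; a higher number here means a weaker inhibitor, a lower number a stronger inhibitor:
Compound 1 `CCOc1ccc2cc(C(=O)/C=C/c3c(/C=C/c4ccc(OC)cc4)cc(OC)cc3OC)c(=O)oc2c1` gives 7070 nM.
Compound 2 `COc1ccc(/C=C/c2cc(OC)cc(OC)c2/C=C/C(=O)c2cc3ccc(Cl)cc3oc2=O)cc1` gives > 60000 nM.
Compound 3 `COc1ccc(/C=C/c2cc(OC)cc(OC)c2/C=C/C(=O)c2cc3cccc(C)c3oc2=O)cc1` gives > 60000 nM.

Compound 2 stands at a limit of this assay rather than at a number. The same limit holds for compound 3, so two of the three shown values sit there (the limit of > 60000 nM in this assay, at which 2 of the 3 values shown sit). Only compound 1 has a numeric value, and the step from it to the chloro analogue reads an at least 8.4-fold higher number from compound 1 to compound 2 (0.92 log units; beyond the scatter), a chloro in place of an ethoxy on an aromatic carbon. The step that the two limits leave unreadable from compound 2 to compound 3 cannot be sized, since both of its ends are limits.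

Compound 4 `COc1ccc(/C=C/c2cc(OC)cc(OC)c2/C=C/C(=O)c2cc3cc(Br)ccc3oc2=O)cc1` differs from compound 2 by a group of 12 heavy atoms (9 carbon, 2 oxygen, 1 bromine; one six-membered aromatic ring of carbon only, one six-membered aromatic ring with 1 hetero atom) in place of a group of 12 heavy atoms (9 carbon, 2 oxygen, 1 chlorine; one six-membered aromatic ring of carbon only, one six-membered aromatic ring with 1 hetero atom), on a carbonyl carbon. Within the data shown here, the only measured step that bears on this position is the one from compound 1 to compound 2, and it ran toward the limit; the step from compound 2 to compound 3 gives no readable size. A change of chloro to bromo on the same part of the shared core is therefore not expected to move compound 4 away from where compound 2 stands, and the expected step is a step that the limit leaves unreadable from compound 2 to compound 4. For compound 4 in this assay the estimate is 80000 nM, within a range from 20000 nM to 300000 nM, most likely reported again only as a limit.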

Compound 4, half-maximal inhibitory concentration: 12100 nM
Estimate against measurement, compound 4: 6.6-fold (0.82 log units) above, outside the stated range (below it).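

In this assay, the group carrying bromine on the carbonyl carbon gives a numeric reading where the groups in compound 2 and compound 3 did not: an at least 4.9-fold lower number from compound 2 to compound 4 (0.69 log units; beyond the scatter) and an at least 4.9-fold lower number from compound 3 to compound 4 (0.69 log units; beyond the scatter). The earlier compounds shown here showed only that changing this part could take the series to its limit, whereas compound 4 shows that a halogen-bearing group here can keep a readable value, so the presence of a halogen alone does not settle the outcome, as compound 2 goes against any such rule. Both steps give only a minimum size, and the step between the two limit compounds cannot be read, as both remain at a limit of the assay: the limit of > 60000 nM in this assay, at which 2 of the 4 values shown sit.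

On these data alone, how large the true gap is between the groups in compound 2 and compound 4 stays open, as does whether the lower number belongs to bromine in particular or to this group as a whole. The compounds shown also leave open how an amine, a carboxylic acid or a fluorine in this group would read.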